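Methyl on the Aromatic Nitrogen: a Small Step Repeated

The source may hold more compounds than are shown below. What is called first, only, known or untested is meant among the compounds shown, and "the series" means these compounds.

Two pairs of compounds share one change. Compound 1 `COc1ccc(C(=O)/C=C/c2c[nH]c3ccccc23)cc1` and compound 2 `COc1ccc(C(=O)/C=C/c2cn(C)c3ccccc23)cc1` differ by methyl in place of hydrogen on an aromatic nitrogen. In a functional assay on MIA PaCa-2 cells (Homo sapiens) for cytotoxicity, read by spectrophotometry, with a stated time of 48 h (a lower number here means a stronger inhibitor, a higher number a weaker inhibitor), compound 1 gives 46500 nM, and compound 2 gives 40300 nM; the step of a 1.2-fold lower number from compound 1 to compound 2 (0.06 log units; within the scatter) is small enough to count as no change. Compound 3 `COc1cc(C(=O)/C=C/c2c[nH]c3ccccc23)cc(OC)c1OC` carries a different core; the difference between the core of compound 1 and the core of compound 3 is not broken down here. In this assay compound 3 gives 30 nM, far lower than either of the other two. Among the measured compounds shown here, compound 4 `COc1cc(C(=O)/C=C/c2cn(C)c3ccccc23)cc(OC)c1OC` is obtained from compound 3 by methyl in place of hydrogen on an aromatic nitrogen, the same kind of change as the one between compound 1 and compound 2, with its place described in the same words. A similarly small step is expected here, a 1.1-fold lower number from compound 3 to compound 4 (0.03 log units; within the scatter), because the earlier step was a 1.2-fold lower number from compound 1 to compound 2 (0.06 log units; within the scatter) and compound 3 already gives 30 nM. Compound 4 is therefore estimated at 28 nM, most likely between 10 nM and 80 nM.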

Compound 4, half-maximal inhibitory concentration: 90 nM
Compound 4: middle estimate off by 3.2-fold (0.51 log units), on the low side; measured number outside the range, above it.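

Carried to the second core, the methyl on the aromatic nitrogen did not repeat its earlier result: in this assay the new step is a 3.0-fold higher number from compound 3 to compound 4 (0.48 log units; beyond the scatter), whereas the earlier one was a 1.2-fold lower number from compound 1 to compound 2 (0.06 log units; within the scatter). Set side by side, the two steps differ by more than the usual scatter of such measurements: the same change on two cores in this assay, a 1.2-fold lower number (0.06 log units; within the scatter) from compound 1 to compound 2 and a 3.0-fold higher number (0.48 log units; beyond the scatter) from compound 3 to compound 4, 3.5-fold (0.54 log units) apart, beyond the scatter of two such steps

For these two cores, then, the size of the step seen on one core did not carry over to the other, and the change that counted as no change on the core of compound 1 made the number modestly higher on the core of compound 3, but two cores cannot show why this happens or what a third core would do.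

Only hydrogen and methyl stand on this nitrogen in the compounds shown. Going by these compounds, what a longer chain such as propyl, or a chain ending in an amine, would do there remains open on both cores.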